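A few compounds are considered here, and "the series" means these few. Any claim that something is new, unique, unknown or untested is made for them only; others in the source may bear on it.

Compound 1 `O=C(Nc1ccc(Cl)cc1)c1c(NO)cc(-c2ccccc2)oc1=O` is tested in an ADME assay on Huh-7 cells (Homo sapiens) for cytotoxicity, read by a luciferase reporter and WST assay, with a stated time of 3 days; a higher number here means that more compound is tolerated, a lower number that less compound is tolerated. In this assay compound 1 gives > 20000 nM, which is a limit of the assay rather than a number. Compound 2 `Cc1ccc(NC(=O)c2c(NO)cc(-c3ccc(Cl)cc3)oc2=O)cc1` in this assay gives > 20000 nM, likewise a limit. Compound 1 thus stands at the limit of > 20000 nM in this assay, at which 2 of the 2 values shown sit. Compound 3 `CCNC(=O)c1c(NO)cc(-c2ccccc2)oc1=O` differs from compound 1 by ethyl in place of 4-chlorophenyl on an amide-type nitrogen. Within the data shown here, no step between measured compounds is available here. Compound 3 is expected to show a step of a number no higher from compound 1 to compound 3 (the limit leaves the size open), none beyond the scatter, and most likely to remain at the limit. Compound 3 is therefore estimated at 20000 nM, between 10000 nM and 40000 nM.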

Compound 3, half-maximal cytotoxic concentration: > 20000 nM
Compound 3: a limit, no number (the forecaster's own chance of this, stated with the estimate: 80%); the middle value lies on the limit itself.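

No step can be read between compound 1 and compound 3, since both values are limits and not numbers: the limit of > 20000 nM in this assay, at which 3 of the 3 values shown sit. The compounds shown leave open whether any group on the amide-type nitrogen would give a readable number.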